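A Methyl and a Second Chlorine on the Six-Membered Ring

This account rests on a few compounds, and the source may have more. Where it says the series, first, only, none or still open, it means among the compounds named here.

Compound 1 `COc1ccc(Cl)c(-c2noc(C(C)C)c2COc2ccc(-c3ccc4c(C(=O)O)cn(C)c4c3)c(C)c2)n1` gives 2000 nM in a functional assay for agonist activity at Bile acid receptor (Mus musculus), read by a luciferase reporter; a higher number here means that more compound is needed for the effect, a lower number that less compound is needed. Compound 2 `Cc1cc(OCc2c(-c3[nH]c(=O)ccc3Cl)noc2C(C)C)ccc1-c1ccc2c(C(=O)O)cn(C)c2c1` gives 18000 nM. Compound 3 `CC(C)c1onc(-c2c(Cl)cncc2Cl)c1COc1ccc(/C=C/c2cccc(C(=O)O)c2)c(Cl)c1` gives 11000 nM.

Among these three, compound 2 has the highest number. Its value and that of compound 3 lie within the usual scatter of each other, so the two cannot be told apart. Against compound 1, however, the gap is real: a 9.0-fold higher number from compound 1 to compound 2 (0.95 log units; beyond the scatter). In that step, a six-membered ring lacking a hydrogen-bond donor was replaced by one carrying a donor, and more compound was needed.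

Compound 4 `Cc1cc(OCc2c(-c3c(Cl)cn(C)c(=O)c3Cl)noc2C(C)C)ccc1-c1ccc2c(C(=O)O)cn(C)c2c1` reverses part of that move. The change is a group of 10 heavy atoms (6 carbon, 1 nitrogen, 1 oxygen, 2 chlorine; one six-membered aromatic ring with 1 hetero atom) in place of a group of 8 heavy atoms (5 carbon, 1 nitrogen, 1 oxygen, 1 chlorine; one six-membered aromatic ring with 1 hetero atom), on an aromatic carbon. The incoming ring carries a methyl on its nitrogen, so the hydrogen-bond donor is gone, and it carries a second chlorine. Among the compounds with values here, the only measured step that bears on this is the one from compound 1 to compound 2, which links the appearance of the donor with a modest rise. Within the data shown here, no measured pair shows what the extra chlorine alone does.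

Removing the donor is therefore expected to lower the number, by a modest step: a 3.0-fold lower number from compound 2 to compound 4 (0.48 log units; beyond the scatter). Compound 4 is estimated at 6000 nM, with a range from 2000 nM to 18000 nM.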

Compound 4, half-maximal effective concentration: 11000 nM
Compound 4: the middle estimate sits 1.8-fold (0.26 log units) below what was measured; the range from low to high includes it.
By their numbers in this assay, from the lowest: compound 1; then compounds 3, 4 and 2 (each within the scatter of the next).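

In this assay, the ring exchange at this carbon of the five-membered ring gives a 1.6-fold lower number from compound 2 to compound 4 (0.21 log units; within the scatter), so compound 2 and compound 4 cannot be told apart even though the hydrogen-bond donor of compound 2 is absent from compound 4. The ring of compound 4 has no such donor, yet the comparison with the methoxy-bearing ring still gives a 5.5-fold higher number from compound 1 to compound 4 (0.74 log units; beyond the scatter), which shows that a ring without this donor can also need clearly more compound, and the donor is therefore not required for the higher number at this position. No supporting measurement is available to explain either result.

The methyl on the ring nitrogen and the second chlorine enter together in compound 4, so the compounds shown leave open what each contributes on its own. They also leave open whether a ring with an ethoxy group or an amine in place of the methoxy group of compound 1 would stay close to compound 1 in this assay or fall with compound 2 and compound 4.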